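From Fluorophenyl to Chlorophenyl on the Ring Nitrogen

A few compounds are considered here, and "the series" means these few. Any claim that something is new, unique, unknown or untested is made for them only; others in the source may bear on it.

Measured so far:
Compound 1, `O=c1[nH]cc(S(=O)(=O)Nc2ccccc2-c2cn(-c3ccccc3)nn2)c(=O)[nH]1`: in a functional assay on SGC-7901 cells (Homo sapiens) for antiproliferative activity, read by MTT assay, with a stated time of 24 h (on this read-out higher numbers stand for weaker inhibition and lower numbers for stronger inhibition), compound 1 gives 11800 nM.
Compound 2, `O=c1[nH]cc(S(=O)(=O)Nc2ccccc2-c2cn(-c3cccc(F)c3)nn2)c(=O)[nH]1`: in this assay compound 2 reaches only > 20000 nM, a limit of the assay rather than a number.

Compound 2 therefore sits at the limit of > 20000 nM in this assay, at which 1 of the 2 values shown sits. Within the data shown here, the only measured step, an at least 1.6-fold higher number from compound 1 to compound 2 (0.22 log units; that floor lies within the scatter), concerns a different change from the one now considered. Compound 3, `O=c1[nH]cc(S(=O)(=O)Nc2ccccc2-c2cn(-c3ccccc3Cl)nn2)c(=O)[nH]1`, differs from compound 2 by 2-chlorophenyl in place of 3-fluorophenyl on an aromatic nitrogen. Among the measured compounds shown here, no measured step covers this swap, so in this assay no step beyond the scatter is expected in either direction. Compound 3 is estimated at 18000 nM, within 7000 nM to 40000 nM, an expected step of an at least 1.1-fold lower number from compound 2 to compound 3 (0.04 log units; that floor lies within the scatter).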

Compound 3, half-maximal inhibitory concentration: 6520 nM
For compound 3 the middle estimate is 2.8-fold (0.44 log units) above the measured one; measured number outside the range, below it.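

In this assay, the swap on the aromatic nitrogen produces a change beyond the scatter: an at least 3.0-fold lower number from compound 2 to compound 3 (0.48 log units; beyond the scatter). Compound 2 stands only at a limit of the assay, so that step is a floor: the limit of > 20000 nM in this assay, at which 1 of the 3 values shown sits A chlorine added to the phenyl ring gives a 1.8-fold lower number from compound 1 to compound 3 (0.26 log units; within the scatter), so the plain phenyl and 2-chlorophenyl groups cannot be told apart here.

The swap alters the halogen and its position together, and the compounds shown do not separate the two. Going by these compounds, how a methoxy group or an amine on that phenyl ring would read also stays open.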